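The source may report more compounds than this note shows. Statements on the series, on what has been measured and on what is new or still open speak of the compounds shown alone.

Three close relatives built on one shared core have been tested in a functional assay on HUVEC cells (Homo sapiens) for cytotoxicity; on this read-out lower numbers stand for an effect already at smaller amounts and higher numbers for an effect only at larger amounts of compound. Compound 1 `COC1=C(C)C(=O)/C(=C(O)/C=C/c2ccc(Br)cc2)C(=O)C1(C)C` gives 3.6 ug/mL. Compound 2 `COC1=C(C)C(=O)/C(=C(O)/C=C/c2ccc(O)cc2)C(=O)C1(C)C` gives 3.8 ug/mL, the highest of the three numbers, yet compound 1 lies only a 1.1-fold higher number from compound 1 to compound 2 (0.02 log units; within the scatter) away and compound 3 `COC1=C(C)C(=O)/C(=C(O)/C=C/c2ccco2)C(=O)C1(C)C` only a 1.6-fold lower number from compound 2 to compound 3 (0.20 log units; within the scatter), both within the scatter. Compound 3 gives 2.4 ug/mL. Compound 4 `COC1=C(C)C(=O)/C(=C(O)/C=C/c2nccs2)C(=O)C1(C)C` has not been measured; it differs from compound 2 by 1,3-thiazol-2-yl in place of 4-hydroxyphenyl on a double-bonded chain carbon bound to a double-bonded chain carbon. Among the measured compounds shown here, the steps that bear on exchanging the six-membered aromatic ring for a five-membered aromatic ring are a 1.5-fold lower number from compound 1 to compound 3 (0.18 log units; within the scatter) and a 1.6-fold lower number from compound 2 to compound 3 (0.20 log units; within the scatter), both within the scatter, so no change beyond the scatter is expected in this assay. Compound 4 is therefore estimated at 3.3 ug/mL, between 1.6 ug/mL and 7 ug/mL. This expected result corresponds to a 1.2-fold lower number from compound 2 to compound 4 (0.06 log units; within the scatter).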

Compound 4, concentration for half-maximal effect: 1.6 ug/mL
Beside the measured number, compound 4's estimate is 2.1-fold (0.31 log units) above it; low and high end bracket the measured number.
By their numbers in this assay, from the lowest: compounds 4, 3, 1 and 2 (each within the scatter of the next, the first and the last beyond it).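

In this assay, a change at this place on the chain now goes beyond the scatter: 1,3-thiazol-2-yl in place of a six-membered aromatic ring gives a 2.4-fold lower number from compound 2 to compound 4 (0.38 log units; beyond the scatter) and a 2.3-fold lower number from compound 1 to compound 4 (0.35 log units; beyond the scatter). The two five-membered rings cannot be told apart, since the exchange of furan-2-yl for 1,3-thiazol-2-yl gives only a 1.5-fold lower number from compound 3 to compound 4 (0.18 log units; within the scatter). No measurement shown explains these steps. The compounds shown leave open whether an aromatic ring is needed here at all. An amine, a carboxylic acid or a longer chain at this place could answer that.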